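The source may hold more compounds than are shown below. What is called first, only, known or untested is meant among the compounds shown, and "the series" means these compounds.

In a physicochemical assay for solubility, at pH 7.4 (a higher number here means a more soluble compound, a lower number a less soluble compound), the measured compounds stand as follows:
- Compound 1 `Cc1csc(C(=O)N[C@H]2CN(S(=O)(=O)c3ccccc3)C[C@@H]2C(=O)N[C@H]2CCCNC2)n1` gives 847000 nM
- Compound 2 `O=C(N[C@H]1CN(S(=O)(=O)c2ccccc2)C[C@@H]1C(=O)N[C@H]1CCCNC1)c1cn(C2CC2)cn1` gives 664000 nM
- Compound 3 `O=C(N[C@H]1CN(S(=O)(=O)c2ccccc2)C[C@@H]1C(=O)N[C@H]1CCCNC1)c1cc(-c2ccccc2)on1` gives 94000 nM

Compound 3 has the lowest number of the three, and it lies beyond the scatter from both of the others. Compound 4 `O=C(N[C@H]1CN(S(=O)(=O)c2ccccc2)C[C@@H]1C(=O)N[C@H]1CCCNC1)c1nnc(-c2ccc(F)cc2)s1` has not yet been measured. It differs from compound 3 in one exchange: a group of 12 heavy atoms (8 carbon, 2 nitrogen, 1 fluorine, 1 sulfur; one five-membered aromatic ring with 3 hetero atoms, one six-membered aromatic ring of carbon only) in place of a group of 11 heavy atoms (9 carbon, 1 nitrogen, 1 oxygen; one five-membered aromatic ring with 2 hetero atoms, one six-membered aromatic ring of carbon only), on a carbonyl carbon. Among the compounds with values here, three measured steps bear on it. The step of a 1.3-fold lower number from compound 1 to compound 2 (0.11 log units; within the scatter) swaps one group without a six-membered aromatic ring of carbon only for another. The steps of a 9.0-fold lower number from compound 1 to compound 3 (0.95 log units; beyond the scatter) and a 7.1-fold lower number from compound 2 to compound 3 (0.85 log units; beyond the scatter) both bring in 5-phenyl-1,2-oxazol-3-yl, and both are modest. Compound 4 keeps a six-membered aromatic ring of carbon only, so neither of those modest steps is expected to repeat in full. Only a small move towards a lower number is expected in this assay, and the data hold no direct measure of this exchange. The expected change is a 1.6-fold lower number from compound 3 to compound 4 (0.19 log units; within the scatter). The estimate for compound 4 is 60000 nM, with an expected range from 15000 nM to 200000 nM.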

Compound 4, solubility: 234000 nM
Compound 4: the middle estimate sits 3.9-fold (0.59 log units) below what was measured; measured number outside the range, above it.
By their numbers in this assay, from the lowest: compound 3; then compound 4; then compounds 2 and 1 (each within the scatter of the next).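

In this assay, the exchange on a carbonyl carbon gives a 2.5-fold higher number from compound 3 to compound 4 (0.40 log units; beyond the scatter), which shows that two groups each holding a six-membered aromatic ring of carbon only can differ beyond the scatter at this position. Even so, the new group still reads under both groups without that ring, with a 2.8-fold lower number from compound 2 to compound 4 (0.45 log units; beyond the scatter) and a 3.6-fold lower number from compound 1 to compound 4 (0.56 log units; beyond the scatter), and among these four compounds none goes against this ordering. Nothing measured here accounts for these differences.

The compounds shown leave open how much of the step from compound 3 to compound 4 belongs to the five-membered aromatic ring and how much to the fluorine, as both change in one exchange. Also open, as far as these compounds go, is how a group carrying an amine or a carboxylic acid would read at this position in this assay.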